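Notes on replacing methoxy with dimethylamino

This account rests on a few compounds, and the source may have more. Where it says the series, first, only, none or still open, it means among the compounds named here.

Measured in a functional assay on PC-3 cells (Homo sapiens) for inhibition, read by MTT assay, with a stated time of 48 h; a higher number here means a weaker inhibitor, a lower number a stronger inhibitor:
- compound 1 `COc1ccc(-n2c(SCc3ccccc3)nnc2-c2cc(OC)c(OC)c(OC)c2)cc1` 34100 nM
- compound 2 `COc1ccc(CSc2nnc(-c3cc(OC)c(OC)c(OC)c3)n2-c2ccc(OC)cc2)cc1` 40300 nM
- compound 3 `COc1ccc(-n2c(SCC(=O)C3CC3)nnc2-c2cc(OC)c(OC)c(OC)c2)cc1` 37200 nM

Compound 2 is not separated from the other two compounds, with a 1.2-fold higher number from compound 1 to compound 2 (0.07 log units; within the scatter) and a 1.1-fold lower number from compound 2 to compound 3 (0.03 log units; within the scatter). The remaining step, a 1.1-fold higher number from compound 1 to compound 3 (0.04 log units; within the scatter), is equally small. Compound 4 `COc1ccc(CSc2nnc(-c3cc(OC)c(OC)c(OC)c3)n2-c2ccc(N(C)C)cc2)cc1` carries dimethylamino in place of methoxy on an aromatic carbon. For the measured compounds named here, no measured step replaces this methoxy, so the evidence is indirect. All three measured changes lie elsewhere and stayed within the scatter, so no step beyond the scatter is expected in this assay, and no direction is favoured. The expected step is a 1.2-fold lower number from compound 2 to compound 4 (0.06 log units; within the scatter). For compound 4 the estimate is 35000 nM, with an expected range of 14000 nM to 70000 nM.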

Compound 4, half-maximal inhibitory concentration: > 60000 nM
Compound 4 gave a limit, no number; the forecaster's own chance of this, stated with the estimate: 10%; at least 1.7-fold (0.23 log units) between middle value and limit.
By their numbers in this assay, from the lowest: compounds 1, 3 and 2 (each within the scatter of the next). At a limit, above all of these: compound 4.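

At the para place on the 4-methoxyphenyl, the move to 4-(dimethylamino)phenyl in this assay gives an at least 1.4-fold higher number from compound 2 to compound 4 (0.17 log units; that floor lies within the scatter), so this floor alone does not separate the two compounds. Compound 4 gave a limit, not a number: the limit of > 60000 nM in this assay, at which 1 of the 4 values shown sits. It is the only compound shown with a change at this place and the only one reported as a limit, while the three changes elsewhere stayed within the scatter.

Going by these compounds, the true size of the step remains open. Also open, on these data alone, is whether a smaller primary amine, a hydroxyl or a carboxylic acid at this place would give a measurable number in this assay.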